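A few compounds are considered here, and "the series" means these few. Any claim that something is new, unique, unknown or untested is made for them only; others in the source may bear on it.

The measured compounds and their numbers in a functional assay on CCRF-CEM cells (Homo sapiens) for cytotoxicity (a lower number here means a stronger inhibitor, a higher number a weaker inhibitor), are: compound 1 `O=C(/C=C/C(=O)N1C/C(=C\c2ccccc2)C(=O)/C(=C/c2ccccc2)C1)Nc1ccc(Cl)c(Cl)c1`, 350 nM; compound 2 `O=C(/C=C/C(=O)N1C/C(=C\c2ccc([N+](=O)[O-])cc2)C(=O)/C(=C/c2ccc([N+](=O)[O-])cc2)C1)Nc1ccc(Cl)c(Cl)c1`, 380 nM; compound 3 `Cc1ccc(NC(=O)/C=C/C(=O)N2C/C(=C\c3ccccc3)C(=O)/C(=C/c3ccccc3)C2)cc1`, 1100 nM.

Compound 2 stands next to compound 1, the two numbers lying within the scatter of each other, while compound 3 gives a number beyond the scatter from that of compound 2. Compound 4 `Cc1cccc(C)c1NC(=O)/C=C/C(=O)N1C/C(=C\c2ccc([N+](=O)[O-])cc2)C(=O)/C(=C/c2ccc([N+](=O)[O-])cc2)C1` arises from compound 2 by 2,6-dimethylphenyl in place of 3,4-dichlorophenyl on an amide-type nitrogen. Within the data shown here, one measured step bears on this change: a 3.1-fold higher number from compound 1 to compound 3 (0.50 log units; beyond the scatter), where a methyl-bearing phenyl replaced the same dichlorophenyl on the amide nitrogen and gave a modest rise in this assay. Among the measured compounds shown here, compound 3 differs from compound 2 in more than one place, so its values show only that the methylphenyl analogue sits higher. For compound 4 a modest rise in this assay is therefore expected, of the order seen from compound 1 to compound 3, i.e. a 2.6-fold higher number from compound 2 to compound 4 (0.42 log units; beyond the scatter). The estimate for compound 4 in this assay is 1000 nM, with a range from 400 nM to 2500 nM.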

Compound 4, half-maximal inhibitory concentration: 230 nM
Estimate against measurement, compound 4: 4.3-fold (0.64 log units) above; measured number outside the range, below it.
By their numbers in this assay, from the lowest: compounds 4, 1 and 2 (each within the scatter of the next); then compound 3.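

In this assay the exchange of 3,4-dichlorophenyl for 2,6-dimethylphenyl on the amide-type nitrogen gives a 1.7-fold lower number from compound 2 to compound 4 (0.22 log units; within the scatter) and so leaves the number of compound 2 essentially in place. The earlier step of a 3.1-fold higher number from compound 1 to compound 3 (0.50 log units; beyond the scatter) had gone beyond the scatter, so a methyl-bearing phenyl on this nitrogen does not by itself go with a higher number, though the two steps differ in both the entering group and the core. Nothing available accounts for the difference between these two steps.

The compounds shown leave open whether 4-methylphenyl would give a higher number on the core of compound 2, and how 2,6-dimethylphenyl would read on the core of compound 1. They also leave open how a phenyl carrying an amine or a carboxylic acid would behave on this nitrogen.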